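Notes on compound 4: phenyl in place of methyl

The source may report more compounds than this note shows. Statements on the series, on what has been measured and on what is new or still open speak of the compounds shown alone.

Measured so far:
compound 1 `Cc1noc(-c2cc3ccccc3[nH]2)n1`: > 50000 nM
compound 2 `Cc1noc(-c2cc3cc(F)ccc3[nH]2)n1`: 12400 nM
compound 3 `Cc1noc(-c2cc3cc(Cl)ccc3[nH]2)n1`: 34400 nM

In a functional assay on MCF7 cells (Homo sapiens) for antiproliferative activity, read by WST assay, with a stated time of 72 h (a lower number here means a stronger inhibitor, a higher number a weaker inhibitor), compound 1 gives > 50000 nM. That figure is a limit of the assay and not a number (the limit of > 50000 nM in this assay, at which 1 of the 3 values shown sits). Compound 2 gives 12400 nM and compound 3 gives 34400 nM. The measured steps are an at least 4.0-fold lower number from compound 1 to compound 2 (0.60 log units; beyond the scatter), an at least 1.4-fold lower number from compound 1 to compound 3 (0.16 log units; that floor lies within the scatter) and a 2.8-fold higher number from compound 2 to compound 3 (0.44 log units; beyond the scatter); all three concern a fluoro or chloro group on an aromatic carbon, and the first two start from the limit of compound 1.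

Compound 4 `c1ccc(-c2noc(-c3cc4ccccc4[nH]3)n2)cc1` differs from compound 1 in one place: phenyl in place of methyl on an aromatic carbon. For the measured compounds named here, none of the measured steps changes anything at that place, so no measured step bears directly on this change, and the starting point is itself a limit. The expectation for compound 4 in this assay therefore rests on little more than the standing of compound 1, and the step of an at least 1.2-fold lower number from compound 1 to compound 4 (0.09 log units; that floor lies within the scatter) is expected to stay within a broad range around that limit. Compound 4 is estimated at 40000 nM, in the range 8000 nM to 150000 nM, with a considerable chance that only a limit is reported.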

Compound 4, half-maximal inhibitory concentration: 45700 nM
Compound 4: middle estimate off by 1.1-fold (0.06 log units), on the low side; measured number inside the range.
By their numbers in this assay, from the lowest: compound 2; then compounds 3 and 4 (each within the scatter of the next). At a limit, above all of these: compound 1.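

For the compounds shown here, at the place between two ring nitrogen atoms, the change from methyl to phenyl is the first measured change, and in this assay the step is an at least 1.0-fold lower number from compound 1 to compound 4 (0.03 log units; that floor lies within the scatter). The value of compound 1, > 50000 nM, is a limit of the assay and not a number. The step therefore gives only a floor that lies within the scatter, so the phenyl group of compound 4 yields a measured value, but the true size of the change from methyl stays unknown, and the limit marks how little of this series can be placed on a scale: the limit of > 50000 nM in this assay, at which 1 of the 4 values shown sits.

Open, as far as these compounds go, is what phenyl would give on the fluoro-bearing core of compound 2, where a number rather than a limit would serve as the starting point. Also open, from the compounds shown here alone, is how an amine, a carboxylic acid or a longer chain at this place would read in this assay.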